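Lengthening an Isothiocyanate Chain on Two Related Cores

This account rests on a few compounds, and the source may have more. Where it says the series, first, only, none or still open, it means among the compounds named here.

Compound 1, with the structure `CN(C)C(=O)c1cc2cnc(Nc3ccc(C(=O)NCCCCCCN=C=S)cc3F)nc2n1C1CCCC1`, and compound 2, with the structure `CN(C)C(=O)c1cc2cnc(Nc3ccc(C(=O)NCCCCCCCN=C=S)cc3F)nc2n1C1CCCC1`, share a core and differ only in the chain that carries the isothiocyanate. In a functional assay on NCI-H1299 cells (Homo sapiens) for inhibition, read by CCK-8 assay, with a stated time of 72 h, tested at 10 uM (on this read-out lower numbers stand for a weaker effect and higher numbers for a stronger effect at the one concentration tested), compound 1 gives 77.6%, while compound 2 gives 35.8%. The change, (a group of 4 heavy atoms (2 carbon, 1 nitrogen, 1 sulfur; no ring) in place of a group of 3 heavy atoms (1 carbon, 1 nitrogen, 1 sulfur; no ring), on a saturated chain carbon, six bonds along the chain from an amide-type nitrogen), brings a number 41.8 percentage points lower from compound 1 to compound 2 (beyond the scatter).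

Compound 3, with the structure `CN(C)C(=O)c1cc2cnc(Nc3ccc(C(=O)NCCCN=C=S)cc3O)nc2n1C1CCCC1`, has a different core; the difference between the two cores is not broken down here. In this assay compound 3 gives 24.2%, the lowest of the three numbers.

Compound 4, with the structure `CN(C)C(=O)c1cc2cnc(Nc3ccc(C(=O)NCCCCN=C=S)cc3O)nc2n1C1CCCC1`, is not yet measured. It differs from compound 3 by a group of 4 heavy atoms (2 carbon, 1 nitrogen, 1 sulfur; no ring) in place of a group of 3 heavy atoms (1 carbon, 1 nitrogen, 1 sulfur; no ring), on a saturated chain carbon, three bonds along the chain from an amide-type nitrogen, the same kind of change as from compound 1 to compound 2, but placed three bonds rather than six bonds along the chain from the amide-type nitrogen. Because compound 1 and compound 2 showed a number 41.8 percentage points lower from compound 1 to compound 2 (beyond the scatter), a step downward is expected for compound 4 as well, though compound 3 already starts low, so the estimated step is a number 14.2 percentage points lower from compound 3 to compound 4 (beyond the scatter). Compound 4 is therefore expected to give about 10%, likely between 0% and 30%.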

Compound 4, a percentage reported as inhibition, at one concentration (the size of the read-out at that concentration, not a potency): 51.8%
For compound 4 the middle estimate is 41.8 percentage points below the measured one; the measured number lies above the stated range.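

In this assay, lengthening the isothiocyanate chain on the core of compound 3 brought a number 27.6 percentage points higher from compound 3 to compound 4 (beyond the scatter), so the change did not keep its direction from one core to the other: the same change on two cores in this assay, a number 41.8 percentage points lower (beyond the scatter) from compound 1 to compound 2 and a number 27.6 percentage points higher (beyond the scatter) from compound 3 to compound 4, 69.4 percentage points apart, beyond the scatter of two such steps

This shows that, in these two pairs, the step seen on one core gave no safe guide to the step on the other. It does not show that the core alone sets the direction, since the two steps also sit at different places, three bonds and six bonds along the chain from an amide-type nitrogen, and core and place cannot be separated with only these two pairs.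

The compounds shown leave open how the number would run with a longer chain on the core of compound 3, and whether the two cores would match when they carry the same chain. They also leave open what an amine or a carboxylic acid in place of the isothiocyanate would give at the end of these chains.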